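Two Cores, One Fluorine, and Three Limits

This account rests on a few compounds, and the source may have more. Where it says the series, first, only, none or still open, it means among the compounds named here.

The study sets two cores side by side, each carrying the same aryl amide side chain. Compound 1 `O=C(COc1c(-c2ccccc2)oc2ccccc2c1=O)Nc1ccccc1` and compound 3 `O=C(COc1ccc2c(=O)cc(-c3ccccc3)oc2c1)Nc1ccccc1` are built from the same atoms joined differently; the difference between the two cores is not broken down here. In a functional assay on NCI-H661 cells (Homo sapiens) for antiproliferative activity, read by MTT assay, with a stated time of 72 h (on this read-out lower numbers stand for stronger inhibition of growth and higher numbers for weaker inhibition of growth), compound 1 gives > 10000 nM, which is a limit of the assay and not a number. Compound 3 in this assay likewise reaches only the limit, > 10000 nM. Compound 2 `O=C(COc1c(-c2ccccc2)oc2ccccc2c1=O)Nc1ccc(F)cc1` arises from compound 1 by fluoro in place of hydrogen on an aromatic carbon. In this assay compound 2 also stops at the limit, > 10000 nM. The step that the two limits leave unreadable from compound 1 to compound 2 therefore has no readable size, because the limit of > 10000 nM in this assay, at which 3 of the 3 values shown sit, gathers every value shown at one point.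

Compound 4 `O=C(COc1ccc2c(=O)cc(-c3ccccc3)oc2c1)Nc1ccc(F)cc1` remains to be measured. It differs from compound 3 by fluoro in place of hydrogen on an aromatic carbon, the same change as that made from compound 1 to compound 2, now carried out on the other core. Going by the values given here, the only guide to its effect is that compound 2 stays at the limit, > 10000 nM, after that change. On this basis compound 4 is expected to show a step that the limit leaves unreadable from compound 3 to compound 4 in this assay, a step of no readable size. The estimate for compound 4 in this assay is 15000 nM, expected to lie between 7000 nM and 50000 nM, most likely reported once more only as a limit.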

Compound 4, concentration for 50% growth inhibition: 5770 nM
Beside the measured number, compound 4's estimate is 2.6-fold (0.41 log units) above it; the measured number lies below the stated range.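

On the core of compound 3, fluoro in place of hydrogen on an aromatic carbon gives in this assay an at least 1.7-fold lower number from compound 3 to compound 4 (0.23 log units; that floor lies within the scatter). Compound 4 is thus the only one of the four compounds that carries a number and not a limit, yet the step is known only as a floor, and that floor does not by itself stand clear of the usual scatter, so a real effect of the fluoro on this core is possible but not shown. Whether the change carries from one core to the other cannot be judged, because the matching step on the core of compound 1 cannot be read, which leaves a single step with nothing to set it against: the limit of > 10000 nM in this assay, at which 3 of the 4 values shown sit.

The compounds shown leave open what other groups would do in the place of the fluoro on the same ring, for example a chloro group, a methoxy group, an amine or a carboxylic acid. They also leave open where compounds 1, 2 and 3 truly lie past their limits, and with that the true size of the step on either core.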